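Cytotoxicity notes: methoxy for chloro on compound 2

The compounds below may be only part of what the source reports. "The series", "measured", "known", "first", "only" and "open" are said of these compounds alone.

Measured so far in an ADME assay on HepG2 cells (Homo sapiens) for cytotoxicity, with a stated time of 72 h; a lower number here means that less compound is needed, a higher number that more compound is needed for the effect:
compound 1 `Cc1cc(NC(=O)c2cc([N+](=O)[O-])ccc2Cl)cc(-c2nc3ccccc3s2)c1O` — > 25000 nM
compound 2 `O=C(Nc1cc(-c2nc3ccccc3s2)ccc1Cl)c1cc([N+](=O)[O-])ccc1Cl` — > 25000 nM
compound 3 `O=C(Nc1nc(-c2ccc(Cl)cc2)cs1)c1cc([N+](=O)[O-])ccc1Cl` — > 27000 nM

Compound 2 stands at a limit in this assay, not at a number (the limit of > 25000 nM in this assay, at which 2 of the 3 values shown sit). Compound 1 stands at the same limit. Compound 3 stands at a separate limit of its own (the limit of > 27000 nM in this assay, at which 1 of the 3 values shown sits). Among the measured compounds shown here, with every reading a limit, no step between measured compounds can be sized, and no ordering of the three can be read from these numbers.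

The untested compound 4 `COc1ccc(-c2nc3ccccc3s2)cc1NC(=O)c1cc([N+](=O)[O-])ccc1Cl` differs from compound 2 in one place: methoxy in place of chloro on an aromatic carbon. The three measured compounds carry the same amide and aryl pieces and all sit at limits; nothing here points to a change in either direction for compound 4. The step from compound 2 to compound 4 is expected to be none beyond the scatter, a step that the limit leaves unreadable from compound 2 to compound 4. Compound 4 is expected to come out at about 30000 nM, with a range of 15000 nM to 60000 nM, and most probably to be reported once more only as a limit.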

Compound 4, half-maximal effective concentration: > 25000 nM
Compound 4 gave a limit, no number; the forecaster's own chance of this, stated with the estimate: 80%; the middle value lies beyond the limit too.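

In this assay compound 4 gives > 25000 nM, a limit and not a number. Among the compounds shown here, with compound 2 at the same limit, no step between compound 2 and compound 4 can be read. The compounds shown leave open whether methoxy in place of chloro changes this read-out at all.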